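A few compounds are considered here, and "the series" means these few. Any claim that something is new, unique, unknown or untested is made for them only; others in the source may bear on it.

- Compound 1 `COC(=O)c1ccc(-n2cc(CCCC(=O)Nc3ccc(C)cc3)nn2)cc1` gives 75700 nM 
- Compound 2 `COC(=O)c1ccc(-n2cc(CCCC(=S)Nc3ccc(C)cc3)nn2)cc1` gives 7900 nM 

In a functional assay on A549 cells (Homo sapiens) for inhibition, read by MTT assay, with a stated time of 72 h (on this read-out higher numbers stand for weaker inhibition and lower numbers for stronger inhibition), compound 1 stands highest of the two numbers, and its gap to compound 2 lies beyond the usual scatter. Compound 3 `COC(=O)c1ccc(-n2cc(CCCC(=O)Oc3ccc(C)cc3)nn2)cc1`, not yet measured, has 4-methylphenoxy in place of (4-methylphenyl)amino on a carbonyl carbon and otherwise keeps the core of compound 1. Among the compounds with values here, no measured pair shows this swap, so the forecast is loose. The estimate is a 2.2-fold lower number from compound 1 to compound 3 (0.34 log units; beyond the scatter) as an expected step toward stronger inhibition, one that may barely clear the scatter. The estimated value for compound 3 is 35000 nM with 10000 nM to 110000 nM as the expected range.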

Compound 3, half-maximal inhibitory concentration: > 100000 nM
Compound 3: a limit, no number; the forecaster's own chance of this, stated with the estimate: 10%; middle value at least 2.8-fold (0.45 log units) from the limit.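

In this assay compound 3 gives > 100000 nM, which is a limit of the assay and not a number. Putting 4-methylphenoxy in place of (4-methylphenyl)amino on a carbonyl carbon gives an at least 1.3-fold higher number from compound 1 to compound 3 (0.12 log units; that floor lies within the scatter), so this swap brings no gain in inhibition. How much inhibition it costs cannot be read, because the result is a limit: the limit of > 100000 nM in this assay, at which 1 of the 3 values shown sits.

The compounds shown leave open how the nitrogen and the amide hydrogen each count. Going by these compounds, an N-methyl-N-(4-methylphenyl)amino group on the same carbonyl carbon, which keeps the nitrogen but has a methyl in place of that hydrogen, remains untested here.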